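A few compounds are considered here, and "the series" means these few. Any claim that something is new, unique, unknown or untested is made for them only; others in the source may bear on it.

The measured compounds in a functional assay on MOLT-4 cells (Homo sapiens) for inhibition, read by sulforhodamine B assay, with a stated time of 48 h (on this read-out higher numbers stand for weaker inhibition of growth and lower numbers for stronger inhibition of growth), are:

compound 1, `COc1ccc(-c2cc(/C=C/C(=O)c3ccc(N)cc3)[nH]n2)cc1`, 9480 nM
compound 2, `COc1cc(-c2cc(/C=C/C(=O)c3ccc(N)cc3)[nH]n2)cc(OC)c1OC`, 8510 nM
compound 3, `COc1ccc(C(=O)/C=C/c2cc(-c3cc(OC)c(OC)c(OC)c3)n[nH]2)cc1`, 6820 nM

Compound 2 stands second highest of the three numbers, and all three lie within the scatter of one another, so none can be called stronger or weaker than the rest. For the measured compounds named here, the only step measured between two compounds differing in one place is a 1.2-fold lower number from compound 2 to compound 3 (0.10 log units; within the scatter), a change of the amino group to methoxy on the far aromatic ring.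

Compound 4, `COc1ccc(-c2cc(/C=C/C(=O)c3ccc(N)cc3)[nH]n2)cc1OC`, differs from compound 2 by hydrogen in place of methoxy on an aromatic carbon. Going by the values given here, no measured step touches this position; the nearest guide is compound 1, which carries a single methoxy and gives a number close to that of compound 2. Compounds 1 and 2 give numbers within the scatter of each other. Because a 1.2-fold lower number from compound 2 to compound 3 (0.10 log units; within the scatter) also sits within the scatter, the step to compound 4 is expected to be small, with no clear direction: a 1.0-fold lower number from compound 2 to compound 4 (0.00 log units; within the scatter). Compound 4 is thus estimated at 8500 nM, with a range from 4000 nM to 18000 nM.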

Compound 4, concentration for total growth inhibition: 16500 nM
Compound 4: middle estimate off by 1.9-fold (0.29 log units), on the low side; the range from low to high includes it.
By their numbers in this assay, from the lowest: compounds 3, 2, 1 and 4 (each within the scatter of the next, the first and the last beyond it).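

For the compounds shown here, compound 4 gives the first direct look at a methoxy group on an aromatic carbon ortho to a methoxy group and meta to a large group. In this assay, taking one away gives a 1.9-fold higher number from compound 2 to compound 4 (0.29 log units; within the scatter) as the step, and adding one gives a 1.7-fold higher number from compound 1 to compound 4 (0.24 log units; within the scatter) as the step, so neither change moves the number beyond the scatter. On these numbers, methoxy and hydrogen at this place cannot be told apart, and nothing here explains the values.

Going by these compounds, whether another group on this aromatic carbon, such as a hydroxyl, a chlorine or an amine, would give a number clearly apart from these stays open. So does whether the same change would matter on a compound with methoxy in place of the amino group on the far ring.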